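The source may report more compounds than this note shows. Statements on the series, on what has been measured and on what is new or still open speak of the compounds shown alone.

Going by the values given here, compound 1 `Cc1ccc(NC(=O)CN2CCN(S(=O)(=O)N3CCC(C)CC3)CC2)cc1` and compound 2 `COc1ccc(Cl)cc1NC(=O)N1CCC2(CC1)CN(S(=O)(=O)N1CCC(C)CC1)C2` are the two measured members of this set. In an assay on HEK293 cells for activation of potassium channel subfamily T member 1 (Homo sapiens), read by thallium flux (on this read-out lower numbers stand for an effect already at smaller amounts and higher numbers for an effect only at larger amounts of compound), compound 1 gives 4100 nM, the lower of the two numbers; compound 2 gives 10000 nM, a gap that lies beyond the scatter. Compound 3 `CC1CCN(S(=O)(=O)N2CCN(CC(=O)Nc3ccc(Cl)cc3)CC2)CC1` differs from compound 1 by chloro in place of methyl on an aromatic carbon. Among the compounds with values here, no measured pair shows this exchange, so the step from compound 1 to compound 3 is expected to stay within the scatter, with no clear direction. The value of compound 3 in this assay is estimated at 3500 nM, within a range from 1200 nM to 10000 nM, meaning an expected step of a 1.2-fold lower number from compound 1 to compound 3 (0.07 log units; within the scatter).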

Compound 3, half-maximal effective concentration: > 10000 nM
Compound 3 ended at the assay's limit (the forecaster's own chance of this, stated with the estimate: 15%); middle value at least 2.8-fold (0.45 log units) away from the limit.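

In this assay the place para to a large group responds to a one-atom exchange: chloro in place of methyl gives an at least 2.4-fold higher number from compound 1 to compound 3 (0.38 log units; beyond the scatter) on the core of compound 1. Compound 3 gives > 10000 nM as a limit of the assay, not a number. The step therefore has a lower bound only, with its true size unresolved: the limit of > 10000 nM in this assay, at which 1 of the 3 values shown sits.

Open, as far as these compounds go, is how methoxy, a nitrile or an amine at this place would compare with methyl. Also open, from the compounds shown here alone, is whether ethyl, a longer chain, would hold the value of compound 1.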